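Swapping the meta halogen on the anilino ring of compound 2

This account rests on a few compounds, and the source may have more. Where it says the series, first, only, none or still open, it means among the compounds named here.

Measured so far:
compound 1 `COc1cc2ncnc(Nc3ccc(Cl)c(C(F)(F)F)c3)c2cc1OCCCCC(=O)Nc1ccc(S(N)(=O)=O)cc1`: 3220 nM
compound 2 `COc1cc2ncnc(Nc3cccc(Cl)c3)c2cc1OCCCCC(=O)Nc1ccc(S(N)(=O)=O)cc1`: 33200 nM

In a functional assay on NCI-H1975 cells (Homo sapiens) for antiproliferative activity, read by MTT assay, with a stated time of 72 h (a lower number here means a stronger inhibitor, a higher number a weaker inhibitor), compound 2 gives 33200 nM, the highest of the two numbers recorded, and its nearest neighbour is compound 1, which in this assay gives 3220 nM. Within the data shown here, the one measured step, a 10-fold higher number from compound 1 to compound 2 (1.01 log units; beyond the scatter), concerns a different change on the same anilino nitrogen and so bears on compound 3 only indirectly, by showing that the anilino substituent pattern matters strongly in this assay.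

Compound 3 `COc1cc2ncnc(Nc3cccc(F)c3)c2cc1OCCCCC(=O)Nc1ccc(S(N)(=O)=O)cc1` differs from compound 2 by fluoro in place of chloro on an aromatic carbon. No measured pair here isolates a chloro-to-fluoro swap, so the direction rests on no shown step. Compound 3 is therefore expected to sit near compound 2 in this assay, with a step of a 1.5-fold higher number from compound 2 to compound 3 (0.18 log units; within the scatter), which is an estimate of modest weakening. For compound 3 the expected value in this assay is 50000 nM, with a range from 15000 nM to 160000 nM.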

Compound 3, half-maximal inhibitory concentration: > 40000 nM
Compound 3: only a limit was reported; the forecaster's own chance of this, stated with the estimate: 20%; the middle value lies beyond the limit too.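

For compound 3 the reading in this assay is a limit and not a number: the limit of > 40000 nM in this assay, at which 1 of the 3 values shown sits. Fluoro in place of chloro on this aromatic carbon gives an at least 1.2-fold higher number from compound 2 to compound 3 (0.08 log units; that floor lies within the scatter), so the floor of the step does not separate the two halogens, and how far compound 3 truly lies from compound 2 stays unknown. The step of an at least 12-fold higher number from compound 1 to compound 3 (1.09 log units; beyond the scatter) is large, which shows that a lone fluoro here, like a lone chloro, leaves the anilino ring far short of the 4-chloro-3-(trifluoromethyl)phenyl group.

From the compounds shown here alone, whether a bromo, a methyl or a nitrile at this position would bring the number back towards that of compound 1 remains open. So does the question of whether the gain in compound 1 comes from its chloro, from its trifluoromethyl, or only from the two together.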